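The source may hold more compounds than are shown below. What is called first, only, known or untested is meant among the compounds shown, and "the series" means these compounds.

Measured in a functional assay on MGC-803 cells (Homo sapiens) for antiproliferative activity, read by CCK-8 assay, with a stated time of 72 h, tested at 2 uM; on this read-out lower numbers stand for a weaker effect and higher numbers for a stronger effect at the one concentration tested:
- compound 1 `Nc1ccccc1NC(=O)c1ccc(CSC(=S)N2CCN(Cc3ccccn3)CC2)cc1` gives 23.4%
- compound 2 `Nc1ccccc1NC(=O)c1ccc(CSC(=S)N2CCc3ccccc32)cc1` gives 44%
- compound 3 `CN(Cc1cccnc1)C(=S)SCc1ccc(C(=O)Nc2ccccc2N)cc1` gives 45.9%

Compound 1 stands lowest of the three in this assay; compound 2 and compound 3 each lie beyond the scatter above it. Compound 4 `Nc1ccccc1NC(=O)c1ccc(CSC(=S)N2CCN(C3CCCCC3)CC2)cc1` differs from compound 1 by cyclohexyl in place of (pyridin-2-yl)methyl on an amine nitrogen in a ring: (pyridin-2-yl)methyl leaves and cyclohexyl enters on an amine nitrogen in a ring of a six-membered non-aromatic ring with 2 nitrogen. Within the data shown here, the only measured step, a number 1.9 percentage points higher from compound 2 to compound 3 (within the scatter), concerns a different group on the thiocarbonyl carbon and lies within the scatter, so it says little about this exchange. Among the measured compounds shown here, no measured step bears directly on it; no step beyond the scatter is therefore expected in this assay. Compound 4 is estimated at 28%, between 12% and 48%, which means an expected step of a number 4.6 percentage points higher from compound 1 to compound 4 (within the scatter).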

Compound 4, a percentage reported as inhibition, at one concentration (the size of the read-out at that concentration, not a potency): 16.9%
Estimate against measurement, compound 4: 11.1 percentage points above; the range from low to high includes it.
By their numbers in this assay, from the lowest: compounds 4 and 1 (each within the scatter of the next); then compounds 2 and 3 (each within the scatter of the next).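

In this assay, among these compounds, cyclohexyl in place of (pyridin-2-yl)methyl on an amine nitrogen in a ring gives a number 6.5 percentage points lower from compound 1 to compound 4 (within the scatter), the first reading of any exchange at this position. At this place, then, a ring of carbon only with no hydrogen-bond acceptor and a pyridine-bearing group cannot be told apart. No measurement at hand offers an explanation for this small step.

From the compounds shown here alone, whether a carboxylic acid, a primary amine or a longer alkyl chain on this nitrogen would move the number beyond the scatter remains open. So does whether a simple methyl group would.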